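Methoxy in place of bromo: from compound 2 to compound 3

A few compounds are considered here, and "the series" means these few. Any claim that something is new, unique, unknown or untested is made for them only; others in the source may bear on it.

Two compounds carry numbers in an in vitro assay on BHK cells for binding affinity to Glucagon receptor (Homo sapiens); a higher number here means a weaker inhibitor, a lower number a stronger inhibitor. Compound 1 `CC(C)(C)[C@H]1CC[C@H](N(Cc2ccc(C(=O)NCCC(=O)O)cc2)C(=O)Nc2cc(C(F)(F)F)cc(C(F)(F)F)c2)CC1` gives 16 nM. Compound 2 `O=C(NC[C@@H](O)C(=O)O)c1ccc(CN(C(=O)Nc2cc(Br)cc(C(F)(F)F)c2)c2ccc(C3=CCCCC3)cc2)cc1` gives 7 nM, the lowest of the two numbers shown; its nearest neighbour on that scale is compound 1, whose number is higher by a gap that lies beyond the usual scatter of this assay. The two compounds differ in more than one place, so the gap between them is noted without a cause.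

Compound 3 `COc1cc(NC(=O)N(Cc2ccc(C(=O)NC[C@@H](O)C(=O)O)cc2)c2ccc(C3=CCCCC3)cc2)cc(C(F)(F)F)c1` has not yet been measured in this assay. It differs from compound 2 in one place: methoxy in place of bromo on an aromatic carbon. In words, methoxy in place of bromo on an aromatic carbon, meta to a trifluoromethyl group. Within the data shown here, no measured pair shows this exchange, so nothing sets the size of the step. The expected step is a 2.0-fold higher number from compound 2 to compound 3 (0.30 log units; within the scatter), a modest move towards a higher number, though a result within the scatter would not surprise. Compound 3 is estimated at 14 nM, with a range from 5 nM to 40 nM.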

Compound 3, half-maximal inhibitory concentration: 14 nM
Beside the measured number, compound 3's estimate shows no gap at the digits printed, within the range that was stated.
By their numbers in this assay, from the lowest: compounds 2, 3 and 1 (each within the scatter of the next, the first and the last beyond it).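

In this assay the exchange on an aromatic carbon, meta to a trifluoromethyl group, gives a 2.0-fold higher number from compound 2 to compound 3 (0.30 log units; within the scatter) and is the only comparison among the compounds shown that isolates this position. The numbers of the 3-bromo-5-(trifluoromethyl)phenyl and 3-methoxy-5-(trifluoromethyl)phenyl compounds cannot be told apart, so at this position a methoxy group, with two heavy atoms and one hydrogen-bond acceptor, serves as well in this assay as a bromo group, with one heavy atom and no hydrogen-bond acceptor; the gap between compound 1 and compound 2 could not show this, as those two differ in more than one place. No measurement at hand bears on the reason for this result.

As far as these compounds go, whether an amine, a nitrile or a longer chain such as ethoxy at this position would also stay within the scatter of compound 2 remains open. Also open, from the compounds shown here alone, is whether the same exchange would give a step of like size on the core of compound 1, or with another group in place of the trifluoromethyl.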